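Cyano for hydroxymethyl in a series held at the limit

A few compounds are considered here, and "the series" means these few. Any claim that something is new, unique, unknown or untested is made for them only; others in the source may bear on it.

Compound 2 (`CN(c1ccncc1)n1cccc1CO`) gives > 20 mg/kg in a functional assay on the whole organism with Mus musculus as the target (a lower number here means that less compound is needed, a higher number that more compound is needed for the effect), as a limit and not a number. Compound 1 (`CN(c1ccncc1)n1cccc1C=O`) gives > 20 mg/kg in this assay and this too is a limit. Compound 3 (`CN(c1ccncc1)n1cccc1CCc1ccccc1`) gives > 20 mg/kg in this assay and this is also a limit. Going by the values given here, compound 2 therefore has no number of its own, and the whole record so far is the limit of > 20 mg/kg in this assay, at which 3 of the 3 values shown sit, with no compound ranked against another.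

Compound 4 (`CN(c1ccncc1)n1cccc1C#N`) carries cyano in place of hydroxymethyl on an aromatic carbon. The counted change is cyano in place of hydroxymethyl on an aromatic carbon and it sits on an aromatic carbon of a five-membered aromatic ring with 1 nitrogen.

Among the compounds with values here, two measured steps bear on it: a step that the two limits leave unreadable from compound 1 to compound 2 and a step that the two limits leave unreadable from compound 2 to compound 3 with neither giving a size or a direction. Compound 4 is expected to report a limit too, given that compound 2 sits at the limit > 20 mg/kg in this assay with no readable step and no direction expected.

The expected step is a step that the limit leaves unreadable from compound 2 to compound 4 and its size is only an estimate. Should a number appear, compound 4 is estimated at 30 mg/kg with 15 mg/kg to 80 mg/kg as the expected range.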

Compound 4, dose for half-maximal effect: > 20 mg/kg
Compound 4 was reported as a limit; the forecaster's own chance of this, stated with the estimate: 85%; the middle value lies beyond the limit too.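

In this assay, going by these compounds alone, compound 4 gives > 20 mg/kg, a limit and not a number, so no step from compound 1 or compound 2 to compound 4 can be read. The series stays where it was: the limit of > 20 mg/kg in this assay, at which 4 of the 4 values shown sit. The compounds shown leave open which group on this aromatic carbon, if any, would give a readable dose.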